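This account rests on a few compounds, and the source may have more. Where it says the series, first, only, none or still open, it means among the compounds named here.

Compound 1 `COc1cc(OC)c(-c2coc3cc(OCC=C(C)C)ccc3c2=O)cc1OC` gives 3800 nM in a functional assay on HUVEC cells (Homo sapiens) for antiproliferative activity, read by MTT assay, with a stated time of 24 h; a lower number here means a stronger inhibitor, a higher number a weaker inhibitor.
Compound 2 `COc1ccc2c(=O)c(-c3cc(OC)c(OC)cc3OC)coc2c1` gives only a limit of this assay, namely > 10000 nM.
Compound 3 `COc1cccc(C(=O)Oc2ccc3c(=O)c(-c4cc(OC)c(OC)cc4OC)coc3c2)c1` likewise gives only a limit, > 10000 nM.

Compound 2 therefore stands at the edge of what this assay reports, with no number of its own; the same holds for one other compound, as the limit of > 10000 nM in this assay, at which 2 of the 3 values shown sit, shows. Compound 4 `COc1cc(OC)c(-c2coc3cc(OCc4ccc(F)cc4)ccc3c2=O)cc1OC` differs from compound 2 in one place: 4-fluorophenyl in place of hydrogen on a saturated chain carbon bound to an oxygen on an aromatic ring. Cut one bond further out, the methoxy of compound 2 becomes a (4-fluorobenzyl)oxy.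

Among the measured compounds shown here, two measured steps bear on this position. Going an at least 2.6-fold higher number from compound 1 to compound 2 (0.42 log units; beyond the scatter) shows that removing the larger chain from this oxygen left compound 2 at the limit, while compound 1 sat at a readable number. Going an at least 2.6-fold higher number from compound 1 to compound 3 (0.42 log units; beyond the scatter) also ended at the limit. The step that the two limits leave unreadable from compound 2 to compound 3 cannot be read, since both ends are limits.

A larger, uncharged ether at this oxygen is thus the one substitution that produced a readable number, in compound 1. Compound 4 is expected to move in that direction, with a step of an at least 2.2-fold lower number from compound 2 to compound 4 (0.34 log units; beyond the scatter). The estimated value for compound 4 is 4500 nM, within 1500 nM to 15000 nM.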

Compound 4, half-maximal inhibitory concentration: > 10000 nM
Compound 4: no number, only a limit (the forecaster's own chance of this, stated with the estimate: 35%); middle value at least 2.2-fold (0.34 log units) away from the limit.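

In this assay compound 4 gives only a limit and not a number, so a larger ether on this oxygen does not by itself give a readable value. Exchanging the chain of compound 1 for 4-fluorobenzyl gives an at least 2.6-fold higher number from compound 1 to compound 4 (0.42 log units; beyond the scatter) and leaves the 3-methylbut-2-en-1-yl ether of compound 1 as the only readable case at this position. The steps from compound 2 and from compound 3 to compound 4 cannot be read, and most of this series sits at one edge of the assay: the limit of > 10000 nM in this assay, at which 3 of the 4 values shown sit.

As far as these compounds go, whether the saturated 3-methylbutyl chain or a longer chain on this oxygen would also give a readable number remains open. So does the effect of an amine or a carboxylic acid at the end of such a chain.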